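Piperazin-1-yl in place of aminoamino: compound 4

The source may report more compounds than this note shows. Statements on the series, on what has been measured and on what is new or still open speak of the compounds shown alone.

Compound 1 `N#Cc1c(NN)nc(SCc2nc3ccccc3[nH]2)nc1-c1ccccc1` carries an aminoamino group on its core; in a functional assay on NCI-H460 cells (Homo sapiens) for cytotoxicity, read by MTT assay, with a stated time of 3 days (on this read-out lower numbers stand for stronger inhibition and higher numbers for weaker inhibition), compound 1 gives 2.6 nM, the lowest number among the three measured compounds. Compound 2 `CNc1nc(SCc2nc3ccccc3[nH]2)nc(-c2ccccc2)c1C#N` has a methyl on that nitrogen instead, and in this assay compound 2 gives 3.2 nM; the step of a 1.2-fold higher number from compound 1 to compound 2 (0.09 log units; within the scatter) lies within the scatter, so the two compounds cannot be ranked. Compound 3 `N#Cc1c(NC(N)=O)nc(SCc2nc3ccccc3[nH]2)nc1-c1ccccc1` bears a carbamoyl on the same nitrogen, and in this assay compound 3 gives 14.7 nM; here a 5.7-fold higher number from compound 1 to compound 3 (0.75 log units; beyond the scatter) and a 4.6-fold higher number from compound 2 to compound 3 (0.66 log units; beyond the scatter) are both beyond the scatter, a modest loss.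

Compound 4 `N#Cc1c(-c2ccccc2)nc(SCc2nc3ccccc3[nH]2)nc1N1CCNCC1` differs from compound 1 by piperazin-1-yl in place of aminoamino on an aromatic carbon. Among the compounds with values here, no measured step introduces a ring at this position; the three measured compounds only show that the small methyl replacement costs nothing beyond the scatter, while the carbamoyl replacement costs modestly. The piperazin-1-yl group is a larger change than either measured replacement, so the outcome is uncertain, and a small to modest loss, of the order seen for compound 3 in a 5.7-fold higher number from compound 1 to compound 3 (0.75 log units; beyond the scatter), is the working expectation. Compound 4 is therefore estimated at 8 nM in this assay, within 2.5 nM to 25 nM. The expected step is a 3.1-fold higher number from compound 1 to compound 4 (0.49 log units; beyond the scatter).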

Compound 4, half-maximal inhibitory concentration: 7.35 nM
Beside the measured number, compound 4's estimate is 1.1-fold (0.04 log units) above it, and the stated range covers the measured number.
By their numbers in this assay, from the lowest: compounds 1 and 2 (each within the scatter of the next); then compounds 4 and 3 (each within the scatter of the next).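

Within the data shown here, the aromatic carbon that held only open-chain nitrogen groups in the earlier compounds now carries a six-membered non-aromatic ring, and in this assay this ring costs only a modest step against both small groups (a 2.8-fold higher number from compound 1 to compound 4 (0.45 log units; beyond the scatter); a 2.3-fold higher number from compound 2 to compound 4 (0.36 log units; beyond the scatter)). Against the ureido group, piperazin-1-yl cannot be told apart (a 2.0-fold lower number from compound 3 to compound 4 (0.30 log units; within the scatter)), so going from ureido to this larger ring adds no step beyond the scatter, and the position accepts a ring while the number stays in the nanomolar range. No measurement on hand accounts for any of these steps.

On these data alone, it remains open whether the second ring nitrogen of piperazin-1-yl contributes to the number or whether the ring alone sets it; morpholin-4-yl or piperidin-1-yl on the same aromatic carbon would separate these two readings. Also open, as far as these compounds go, is how far this position tolerates further growth, for example a 4-methylpiperazin-1-yl or 4-acetylpiperazin-1-yl group, and whether an open-chain dimethylamino group would stay with the small groups or fall with the ring.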